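Aryl change on the shared core: compound 3 to compound 4

The compounds below may be only part of what the source reports. "The series", "measured", "known", "first", "only" and "open" are said of these compounds alone.

Compound 1 `Cc1nc(-c2ccc(Cl)cc2)sc1C(=O)CSc1nc(-c2ccc(Cl)c(Cl)c2)c(C#N)c(=O)[nH]1` gives 93.9% in a functional assay on U-87MG ATCC cells for antiproliferative activity against U-87 MG (Homo sapiens), read by MTT assay, with a stated time of 48 h, tested at 50 uM; on this read-out lower numbers stand for a stronger effect and higher numbers for a weaker effect at the one concentration tested.
Compound 2 `Cc1nc(-c2ccc(Cl)cc2)sc1C(=O)CSc1nc(-c2ccccc2)c(C#N)c(=O)[nH]1` gives 41.6%.
Compound 3 `COc1cccc(-c2nc(SCC(=O)c3sc(-c4ccc(Cl)cc4)nc3C)[nH]c(=O)c2C#N)c1` gives 47.6%.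

Compound 3 stands second highest of the three; the gap a number 6 percentage points higher from compound 2 to compound 3 (within the scatter) lies within the scatter, while compound 1 sits far above it, as a number 46.3 percentage points lower from compound 1 to compound 3 (beyond the scatter) shows. Compound 4 `Cc1nc(-c2ccc(Cl)cc2)sc1C(=O)CSc1nc(-c2ccc(Cl)cc2)c(C#N)c(=O)[nH]1` differs from compound 3 by 4-chlorophenyl in place of 3-methoxyphenyl on an aromatic carbon. Among the measured compounds shown here, the steps that bear on this are a number 52.3 percentage points lower from compound 1 to compound 2 (beyond the scatter) and a number 46.3 percentage points lower from compound 1 to compound 3 (beyond the scatter), both large, both away from the 3,4-dichlorophenyl of compound 1. Compound 4 carries one chlorine, so an upward step smaller than the return to compound 1 is expected, estimated as a number 20.4 percentage points higher from compound 3 to compound 4 (beyond the scatter). Compound 4 is therefore estimated at 68%, within 42% to 94%.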

Compound 4, a percentage reported as activity, at one concentration (the size of the read-out at that concentration, not a potency): 60%
The estimate for compound 4 lay 8 percentage points above the measured number; low and high end bracket the measured number.
By their numbers in this assay, from the lowest: compounds 2 and 3 (each within the scatter of the next); then compound 4; then compound 1.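

In this assay, a single chloro on the phenyl at this position already shifts the read-out towards a weaker effect, with a number 18.4 percentage points higher from compound 2 to compound 4 (beyond the scatter), and the 4-chlorophenyl also separates from the 3-methoxyphenyl, with a number 12.4 percentage points higher from compound 3 to compound 4 (beyond the scatter). The second chloro of the 3,4-dichlorophenyl accounts for the larger share of the rise, since hydrogen in its place gives a number 33.9 percentage points lower from compound 1 to compound 4 (beyond the scatter). Nothing available explains these steps.

Open, as far as these compounds go, is how an amine or a carboxylic acid on this phenyl would read, and whether the rise with chloro carries over to bromo.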